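This account rests on a few compounds, and the source may have more. Where it says the series, first, only, none or still open, it means among the compounds named here.

Going by the values given here, compound 2, `COc1cc(NC(C)CCCN2C(=O)CN(C(=O)[C@@H](C)N)C2(C)C)c2ncccc2c1`, is the more soluble of the two compounds measured so far: in a physicochemical assay for solubility (a lower number here means a less soluble compound, a higher number a more soluble compound), compound 2 gives 120000 ug/mL. Its nearest neighbour, compound 1, `COc1cc(NC(C)CCCN2C(=O)CN(C(=O)[C@H](N)C(C)C)C2(C)C)c2ncccc2c1`, differs in one place, a methyl in place of an isopropyl on a saturated chain carbon bound to an amine nitrogen and a carbonyl carbon, and in this assay compound 1 gives 46500 ug/mL; that step was a 2.6-fold higher number from compound 1 to compound 2 (0.41 log units; beyond the scatter).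

Compound 3, `CC[C@H](C)[C@@H](N)C(=O)N1CC(=O)N(CCCC(C)Nc2cc(OC)cc3cccnc23)C1(C)C`, has not yet been measured. It differs from compound 2 in the same place: sec-butyl in place of methyl on a saturated chain carbon bound to an amine nitrogen and a carbonyl carbon.

Among the compounds with values here, the only step that bears on this change is the one from compound 1 to compound 2, where an isopropyl was exchanged for a methyl and the number rose by a 2.6-fold higher number from compound 1 to compound 2 (0.41 log units; beyond the scatter). The change to compound 3 runs the other way, and the sec-butyl that enters carries one more carbon than the isopropyl that left in that step. A fall beyond the scatter is therefore expected, by about a 3.0-fold lower number from compound 2 to compound 3 (0.48 log units; beyond the scatter). Compound 3 is estimated to give 40000 ug/mL in this assay, within a range of 15000 ug/mL to 100000 ug/mL.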

Compound 3, solubility: 29700 ug/mL
The estimate for compound 3 lay 1.3-fold (0.13 log units) above the measured number; the range from low to high includes it.
By their numbers in this assay, from the lowest: compounds 3 and 1 (each within the scatter of the next); then compound 2.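

With sec-butyl in place of methyl on a saturated chain carbon bound to an amine nitrogen and a carbonyl carbon, this assay records a clear drop (a 4.0-fold lower number from compound 2 to compound 3 (0.61 log units; beyond the scatter)), so the gap first seen between isopropyl and methyl now appears with a second branched group as well. The new compound also gives the first look at what happens when the group at this position grows beyond isopropyl: a methyl in place of hydrogen on a saturated chain carbon, three bonds along the chain from an amine nitrogen and a carbonyl carbon, leaves the two compounds indistinguishable (a 1.6-fold lower number from compound 1 to compound 3 (0.19 log units; within the scatter)), so among these three compounds, methyl stands apart while isopropyl and sec-butyl cannot be ordered. No measurement presented here accounts for either of these results.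

The compounds shown carry only methyl, isopropyl and sec-butyl at this position, so it remains open whether the branching or the number of carbons matters more, a question that an ethyl group or a straight butyl chain could help to settle. They also leave open how a group bearing a hydroxyl or a carboxylic acid would read in this assay at this same position.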